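Widening a Ring on the Amide of Compound 2

The source may report more compounds than this note shows. Statements on the series, on what has been measured and on what is new or still open speak of the compounds shown alone.

Three compounds share one core and carry a nitrile on a pyrrolidine joined through a carbonyl. In an assay on the whole organism (plasma, strain Sprague-Dawley) for inhibition of Dipeptidyl peptidase 4 (Rattus norvegicus), with a stated time of 10 h, at a dose of 1 mg/kg by the oral route (on this read-out higher numbers stand for more inhibition at the one dose given (going by the name of the read-out) and lower numbers for less inhibition), compound 2 `C[C@@H]1N[C@H](C(=O)N2CCC[C@H]2C#N)C[C@@H]1C(=O)N1CCC1` gives 88%, the highest of the two numbers available, and compound 3 `N#C[C@@H]1CCCN1C(=O)[C@@H]1C[C@H](C(N)=O)CN1` gives 20%, a result that sits a long way below that of compound 2, well beyond the usual scatter of such measurements. For compound 1 `N#C[C@@H]1CCCN1C(=O)[C@@H]1C[C@H](C(=O)N2CCCCCCC2)CN1` the entry in this assay reads "not determined" (no result reported), so it adds nothing to the comparison.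

Compound 4 `C[C@@H]1N[C@H](C(=O)N2CCC[C@H]2C#N)C[C@@H]1C(=O)N1CCCCC1` is the next step from compound 2. It differs in one place only: piperidin-1-yl in place of azetidin-1-yl on a carbonyl carbon. Both groups are saturated rings with one nitrogen and neither carries a hydrogen-bond donor or acceptor.

No measured pair among these compounds shows a change of exactly this kind, so the direction is open. The large drop from compound 2 to compound 3 involves a different alteration and gives no guide here. The expectation is that compound 4 stays close to compound 2, a step of a number 3 percentage points lower from compound 2 to compound 4 (within the scatter), no larger than the scatter. Compound 4 is expected to give about 85%, between 65% and 95%.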

Compound 4, a percentage reported as inhibition, in the whole organism at one dose (the size of the read-out at that dose, not a potency): 81%
Beside the measured number, compound 4's estimate is 4 percentage points above it, within the range that was stated.
By their numbers in this assay, from the lowest: compound 3; then compounds 4 and 2 (each within the scatter of the next).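

In this assay, the exchange of azetidin-1-yl for piperidin-1-yl on a carbonyl carbon gives a number 7 percentage points lower from compound 2 to compound 4 (within the scatter) and so leaves no readable difference between the two compounds. For the compounds shown here, this is the first pair in the set that differs in one place only, and it shows that this position on the shared core can hold a saturated ring of 6 heavy atoms as well as one of 4 heavy atoms without a change beyond the scatter at this one dose and time. Nothing measured here gives a reason why the read-out holds steady across this change.

Going by these compounds, both rings compared are saturated, with a single nitrogen and no hydrogen-bond donors or acceptors, so it remains open how a morpholin-4-yl ring, a piperazin-1-yl ring or an open-chain diethylamino group would fare on the same carbonyl carbon. Also open, on these data alone, is whether compound 2 and compound 4 would remain this close at a lower dose or at another time after dosing, where a difference hidden in a single reading might show.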